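This account rests on a few compounds, and the source may have more. Where it says the series, first, only, none or still open, it means among the compounds named here.

Series notes, amide-linked dithiocarbamates. Compound 1 `Nc1ccccc1NC(=O)c1ccc(CSC(=S)N2CCN(C(c3ccccc3)c3ccccc3)CC2)cc1` stands lowest of the three numbers measured in a functional assay on MGC-803 cells (Homo sapiens) for antiproliferative activity, read by CCK-8 assay, with a stated time of 72 h, tested at 2 uM; a higher number here means a stronger effect of the compound at the concentration tested, a lower number a weaker effect: compound 1 gives 9.8%. The nearest neighbour is compound 3 `Nc1ccccc1NC(=O)c1ccc(CSC(=S)N2CCc3cc([N+](=O)[O-])ccc32)cc1`, which in this assay gives 26.8%, a reading beyond the scatter above compound 1. The furthest is compound 2 `CCN(Cc1ccncc1)C(=S)SCc1ccc(C(=O)Nc2ccccc2N)cc1`, which in this assay gives 71.6%, also beyond the scatter above compound 1. Among the compounds with values here, no two of the three measured compounds differ in a single place, so no measured step can be set beside the change to the next compound.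

Compound 4 `Nc1ccccc1NC(=O)c1ccc(CSC(=S)N2CCN(Cc3ccccc3)CC2)cc1` has not yet been measured in this assay. Its difference from compound 1: hydrogen in place of phenyl on a saturated chain carbon bound to an amine nitrogen in a ring and an aromatic carbon. Nothing in the measured set is a step of this kind; the change is a loss of a phenyl and nothing more, while the shared core of compound 1 is kept. The expected step in this assay is modest and upward, though a result within the scatter would not surprise: a number 12.2 percentage points higher from compound 1 to compound 4 (beyond the scatter). Compound 4 is estimated at 22%, within a range of 5% to 50% in this assay.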

Compound 4, a percentage reported as inhibition, at one concentration (the size of the read-out at that concentration, not a potency): 18.1%
For compound 4 the middle estimate is 3.9 percentage points above the measured one, and the stated range covers the measured number.
By their numbers in this assay, from the lowest: compounds 1, 4 and 3 (each within the scatter of the next, the first and the last beyond it); then compound 2.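

In this assay the series now has its first single-place step, a number 8.3 percentage points higher from compound 1 to compound 4 (within the scatter), with hydrogen in place of phenyl on a saturated chain carbon bound to an amine nitrogen in a ring and an aromatic carbon. The two readings cannot be told apart at this concentration, so losing this phenyl, with the shared core kept, has no effect that can be resolved here, and the second phenyl on that carbon is not shown to matter for the reading. No measurement at hand bears on what lies behind this result.

Still open, going by these compounds, is whether a methyl on that same carbon, or a methoxy or a fluorine on the remaining phenyl, would give a step beyond the scatter. Within the data shown here, also open is how this pair relates to compound 2 at 71.6%, since no single-place step yet ties compound 2 to either of them, and a step that replaces the ring amine with an open-chain amine would be needed to connect them.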